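Side-chain growth in a bis-aryl series: next step

This account rests on a few compounds, and the source may have more. Where it says the series, first, only, none or still open, it means among the compounds named here.

Measured in a functional assay on HL-60 cells (Homo sapiens) for cytotoxicity, read by WST assay, with a stated time of 48 h; on this read-out higher numbers stand for weaker inhibition and lower numbers for stronger inhibition:
- compound 1 `COc1cc(C(c2ccc(O)c(OC)c2)[C@@H](C)C(C)C)ccc1O`: 20000 nM
- compound 2 `CC[C@H](C(C)C)C(c1ccc(O)c(OC)c1)c1ccc(O)c(OC)c1`: 16000 nM

Among the compounds with values here, compound 2 stands level with compound 1, the only other measured compound, since the two values lie within the scatter of each other. Compound 3 `COc1cc(C(c2ccc(O)c(OC)c2)[C@H](CC(C)C)C(C)C)ccc1O` differs from compound 2 by isopropyl in place of methyl on a saturated chain carbon, three bonds along the chain from two aromatic carbons. Within the data shown here, the only measured step that bears on this change is a 1.3-fold lower number from compound 1 to compound 2 (0.10 log units; within the scatter). That single small step sets no trend, and the change to compound 3 adds more carbon than it did. No clear shift beyond the scatter is therefore expected in this assay, with at most a slight lean towards a lower number. The expected step is a 1.5-fold lower number from compound 2 to compound 3 (0.16 log units; within the scatter). For compound 3 the estimated value is 11000 nM, with an expected range of 4000 nM to 25000 nM.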

Compound 3, half-maximal inhibitory concentration: 9600 nM
Estimate against measurement, compound 3: 1.1-fold (0.06 log units) above; the measured number falls inside the stated range.
By their numbers in this assay, from the lowest: compounds 3, 2 and 1 (each within the scatter of the next, the first and the last beyond it).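

In this assay, isopropyl in place of methyl on a saturated chain carbon, three bonds along the chain from two aromatic carbons, gives a 1.7-fold lower number from compound 2 to compound 3 (0.22 log units; within the scatter), so this change alone does not separate the two compounds. Over the whole group, 1-isopropyl-3-methylbutyl in place of 1,2-dimethylpropyl gives a 2.1-fold lower number from compound 1 to compound 3 (0.32 log units; beyond the scatter), the first step in this set to pass the scatter, though modestly, and the larger branched chain is accepted here without a higher number. No supporting data bear on why this step occurs.

On these data alone, whether branching matters or carbon count alone is enough stays open, and a straight pentyl chain in place of the isopropyl would address this. Equally open, as far as these compounds go, is how an amine or a carboxylic acid at this place would read out in this assay.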